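The source may hold more compounds than are shown below. What is called first, only, known or untested is meant among the compounds shown, and "the series" means these compounds.

In a functional assay on MCF7 cells (Homo sapiens) for inhibition, read by MTT assay, with a stated time of 48 h, tested at 10 uM (on this read-out lower numbers stand for less inhibition of growth and higher numbers for more inhibition of growth at the one concentration tested), three compounds with a shared core have been measured. Compound 1 (`Cc1cc(=O)c2c(O)cc(OCc3ccc([N+](=O)[O-])cc3)c([C@H]3CCN(C)C[C@H]3O)c2o1`) gives 39%. Compound 2 (`Cc1cc(=O)c2c(O)c(CN3CCC(Cc4ccccc4)CC3)c(O)c([C@H]3CCN(C)C[C@H]3O)c2o1`) gives 17%, and compound 3 (`Cc1oc2c([C@H]3CCN(C)C[C@H]3O)c(O)cc(O)c2c(=O)c1C(O)c1ccc(F)c(Br)c1`) gives 14%. These last two values lie within the usual scatter of each other, and both sit clearly under the value of compound 1, so compound 3 belongs to the low end of this small set.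

Compound 4 (`Cc1oc2c([C@H]3CCN(C)C[C@H]3O)c(O)cc(O)c2c(=O)c1C(O)c1ccc(F)cc1`) is compound 3 with hydrogen in place of bromo on an aromatic carbon, which turns 3-bromo-4-fluorophenyl into 4-fluorophenyl: hydrogen in place of bromo on an aromatic carbon. The change sits ortho to a fluoro group and meta to a large group. For the measured compounds named here, no two measured compounds differ in one place alone, so the data give no direct guide to the effect of this swap. The expectation therefore stays near compound 3 at 14%, with no change beyond the scatter. The estimated step is a number 1 percentage points higher from compound 3 to compound 4 (within the scatter). For compound 4 the expected value is 15%, within an estimated range from 3% to 30%.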

Compound 4, percent growth inhibition at one concentration: 9%
Compound 4: the middle estimate sits 6 percentage points above what was measured, within the range that was stated.
By their numbers in this assay, from the lowest: compounds 4, 3 and 2 (each within the scatter of the next); then compound 1.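

For the compounds shown here, putting hydrogen in place of bromo on this aromatic carbon, ortho to a fluoro group, gives in this assay a number 5 percentage points lower from compound 3 to compound 4 (within the scatter), the first step in this set between two compounds that differ in one place only. The two compounds therefore cannot be told apart in this test: the 3-bromo-4-fluorophenyl and the 4-fluorophenyl versions read the same within normal repeat variation, so the bromo shows no measurable contribution here. Nothing available explains this outcome or says how the compounds act in the cells.

As far as these compounds go, whether an amine, a carboxylic acid or a methoxy group on this same carbon would move the number beyond the scatter remains open. From the compounds shown here alone, the role of the fluoro group also remains open, as does that of the hydroxymethyl link holding the ring to the shared core.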